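The compounds below may be only part of what the source reports. "The series", "measured", "known", "first", "only" and "open" are said of these compounds alone.

In a physicochemical assay for metabolic stability, read by HPLC and mass spectrometry, in phosphate buffer, at 37 degrees C, at pH 7.4 (on this read-out higher numbers stand for a longer-lived compound and lower numbers for a shorter-lived compound), compound 1 (`C[C@@H]1CN(C[C@@H]2[C@H](NC(=O)/C(=N\OC(C)(C)C(=O)O)c3csc(N)n3)C(=O)N2S(=O)(=O)O)C(=O)O1`) gives > 37 h, which is a limit of the assay and not a number. In this assay compound 2 (`CC(C)(O/N=C(\C(=O)N[C@@H]1C(=O)N(S(=O)(=O)O)[C@@H]1CN1C[C@@H](CN)OC1=O)c1csc(N)n1)C(=O)O`) gives > 37 h, which is likewise a limit. Compound 2 therefore has no number of its own, and the record so far reads (the limit of > 37 h in this assay, at which 2 of the 2 values shown sit).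

Compound 3 (`CC(C)(O/N=C(\C(=O)N[C@@H]1C(=O)N(S(=O)(=O)O)[C@@H]1CN1C[C@@H](CNC(=N)N)OC1=O)c1csc(N)n1)C(=O)O`) follows from compound 2 by one change, (a group of 3 heavy atoms (1 carbon, 2 nitrogen; no ring) in place of a hydrogen atom, on an amine nitrogen), made on an amine nitrogen whose other neighbours are: saturated chain carbon. Within the data shown here, only one measured step bears on this change. That step, a step that the two limits leave unreadable from compound 1 to compound 2, put amino in place of hydrogen on a saturated chain carbon bound to a saturated ring carbon, and it offers no size to carry forward. Among the measured compounds shown here, with a step that the two limits leave unreadable from compound 1 to compound 2 as the only guide, no shift beyond the usual scatter is expected in this assay, and no direction can be favoured. The expected step is a step that the limit leaves unreadable from compound 2 to compound 3, and another limit may well be what the assay reports. For compound 3 the estimated half-life is 45 h, with an expected range from 20 h to 100 h.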

Compound 3, half-life: > 37 h
Compound 3 was reported as a limit; the forecaster's own chance of this, stated with the estimate: 65%; the middle value does not contradict the limit.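

Among these compounds, compound 1, compound 2 and compound 3 each give only a limit in this assay and not a number, so no step among them can be read: the limit of > 37 h in this assay, at which 3 of the 3 values shown sit. As far as these compounds go, how far the half-life would shift with the amino group or with the group of 3 heavy atoms on the amine nitrogen, and in which direction, stays open.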